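The source may hold more compounds than are shown below. What is called first, only, known or untested is meant among the compounds shown, and "the series" means these compounds.

Measured in a functional assay on HepG2 cells (Homo sapiens) for cytotoxicity, read by MTT assay, with a stated time of 72 h; a lower number here means a stronger inhibitor, a higher number a weaker inhibitor:
- compound 1 `O=C(N/N=C/c1ccc([N+](=O)[O-])cc1)Nc1cc2c(Nc3ccc(F)c(Cl)c3)ncnc2cc1O[C@H]1CCOC1`: 35300 nM
- compound 2 `COc1ccc(/C=N/NC(=O)Nc2cc3c(Nc4ccc(F)c(Cl)c4)ncnc3cc2O[C@H]2CCOC2)cc1`: 28800 nM
- compound 3 `O=C(N/N=C/c1ccc(O)cc1O)Nc1cc2c(Nc3ccc(F)c(Cl)c3)ncnc2cc1O[C@H]1CCOC1`: 4530 nM

Compound 2 sits at the high end of the numbers in this assay, not separated from its nearest neighbour: a 1.2-fold lower number from compound 1 to compound 2 (0.09 log units; within the scatter). The clearly lower number belongs to the dihydroxy analogue: a 6.4-fold lower number from compound 2 to compound 3 (0.80 log units; beyond the scatter).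

Compound 4 `CCN(CC)c1ccc(/C=N/NC(=O)Nc2cc3c(Nc4ccc(F)c(Cl)c4)ncnc3cc2O[C@H]2CCOC2)c(O)c1` has not been measured. Its change from compound 2 is 4-(diethylamino)-2-hydroxyphenyl in place of 4-methoxyphenyl on a carbon with a double bond to nitrogen. The entering group is a 4-(diethylamino)-2-hydroxyphenyl on the carbon with a double bond to nitrogen.

Going by the values given here, the closest precedent is compound 3, whose 2,4-dihydroxyphenyl is also a hydroxyphenyl and which gave a modest step: a 6.4-fold lower number from compound 2 to compound 3 (0.80 log units; beyond the scatter). The parallel step from the nitro analogue was of similar size: a 7.8-fold lower number from compound 1 to compound 3 (0.89 log units; beyond the scatter). The exchange of nitro for methoxy stayed within the scatter: a 1.2-fold lower number from compound 1 to compound 2 (0.09 log units; within the scatter). Among the compounds with values here, no measured compound carries a diethylamino group, so that part of the change is untested, and the expectation is a lower number of modest size, held with some caution.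

The expected move is a 4.1-fold lower number from compound 2 to compound 4 (0.61 log units; beyond the scatter). For compound 4 the estimated value is 7000 nM, with an expected range from 2500 nM to 20000 nM.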

Compound 4, half-maximal inhibitory concentration: 15700 nM
The estimate for compound 4 lay 2.2-fold (0.35 log units) below the measured number; measured number inside the range.
By their numbers in this assay, from the lowest: compound 3; then compounds 4, 2 and 1 (each within the scatter of the next, the first and the last beyond it).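

In this assay, the 4-(diethylamino)-2-hydroxyphenyl group on the carbon with a double bond to nitrogen is not separated from the 4-methoxyphenyl group (a 1.8-fold lower number from compound 2 to compound 4 (0.26 log units; within the scatter)), so a hydroxyphenyl at this place does not by itself bring the lower number seen with compound 3. Going by these compounds alone, the single exchange of hydroxy for diethylamino on an aromatic carbon is the first direct reading of that second substituent, and it gives a modest rise (a 3.5-fold higher number from compound 3 to compound 4 (0.54 log units; beyond the scatter)), which shows that the number at this place depends on more than the shared 2-hydroxy group. The new group still reads modestly lower than the 4-nitrophenyl group (a 2.2-fold lower number from compound 1 to compound 4 (0.35 log units; beyond the scatter)), but no supporting data bear on why any of these steps takes its size.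

Open, from the compounds shown here alone, is whether the lower number of compound 3 needs the second hydroxy specifically, or whether an amino or dimethylamino group on that aromatic carbon would give a similar reading. Also open, going by these compounds, is how a 2-hydroxyphenyl carrying no further group would read, which would separate the contribution of the single hydroxy from that of the second substituent.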